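The source may report more compounds than this note shows. Statements on the series, on what has been measured and on what is new or still open speak of the compounds shown alone.

Measured in a functional assay on HEK293 cells for agonist activity at Free fatty acid receptor 1 (Homo sapiens), read by calcium flux (on this read-out lower numbers stand for an effect already at smaller amounts and higher numbers for an effect only at larger amounts of compound), so far:
compound 1 `CCCCCCCOc1ccc(C(CC(=O)O)c2ccccc2)cc1`: 4.26 uM
compound 2 `CCCCOc1ccc(C(CC(=O)O)c2cccc(F)c2)cc1`: 1.44 uM
compound 3 `CCCCOc1ccc(C(CC(=O)O)c2cccc(C(F)(F)F)c2)cc1`: 2.84 uM

Compound 2 gives the lowest number of the three in this assay. Its nearest neighbour is compound 3, with a 2.0-fold higher number from compound 2 to compound 3 (0.29 log units; within the scatter); compound 1 gives a higher number than compound 2, and that gap lies beyond the scatter, but the two compounds differ in more than one place, so the comparison shows only the two values.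

Compound 4 `CCCCOc1ccc(C(CC(=O)O)c2ccccc2O)cc1` is not yet measured. Relative to compound 2 the change is 2-hydroxyphenyl in place of 3-fluorophenyl on a saturated chain carbon bound to an aromatic carbon and a saturated chain carbon. For the measured compounds named here, the only measured step on the same ring is the one from compound 2 to compound 3, a 2.0-fold higher number from compound 2 to compound 3 (0.29 log units; within the scatter), a swap of one substituent for another at the same place that stayed within the scatter. Going by the values given here, no measured step brings in a hydroxyl, a hydrogen-bond donor or a shift of the substituent to another place on the ring, so the present step has no close precedent. Among the compounds with values here, on the single relevant step, a change of a 1.7-fold higher number from compound 2 to compound 4 (0.24 log units; within the scatter) is expected, with no direction firmly indicated. For compound 4 a value of 2.5 uM is estimated, within a range of 0.8 uM to 8 uM.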

Compound 4, concentration for half-maximal effect: 4.8 uM
Beside the measured number, compound 4's estimate is 1.9-fold (0.28 log units) below it; the measured number falls inside the stated range.
By their numbers in this assay, from the lowest: compounds 2, 3, 1 and 4 (each within the scatter of the next, the first and the last beyond it).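

In this assay, the group on the saturated chain carbon bound to an aromatic carbon and a saturated chain carbon now gives a step beyond the scatter: 2-hydroxyphenyl in place of 3-fluorophenyl gives a 3.3-fold higher number from compound 2 to compound 4 (0.52 log units; beyond the scatter). The earlier swap at this place, a 2.0-fold higher number from compound 2 to compound 3 (0.29 log units; within the scatter), stayed within the scatter, so the number here can respond to the choice of group, though this single step changes the substituent, its place on the ring and the hydrogen-bond donor and acceptor counts together. Nothing available explains the shift or separates these changes.

Still open, as far as these compounds go, is how 2-fluorophenyl and 3-hydroxyphenyl would read here, which would separate the substituent from its place on the ring. A methoxy group or an amine in place of the hydroxyl would show whether the hydroxyl itself matters.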